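The compounds below may be only part of what the source reports. "The series", "measured", "known", "first", "only" and "open" are said of these compounds alone.

Measured so far:
- compound 1, `O=Cc1c(-c2ccccc2)sc2ccccc12`, gives 42%
- compound 2, `N#Cc1ccccc1-c1cc2ccccc2s1`, gives 56%

Of the compounds shown here, two built on the same fused core have been tested in a functional assay on KB cells (Homo sapiens) for cytotoxicity, tested at 10 uM; on this read-out lower numbers stand for less inhibition and higher numbers for more inhibition at the one concentration tested (going by the name of the read-out). Compound 1 carries a formyl group together with a phenyl ring, and in this assay compound 1 gives 42%. Compound 2 replaces the plain phenyl ring with one carrying a nitrile, and in this assay compound 2 gives 56%. Compound 2 therefore stands highest of the two numbers, and the gap to compound 1 lies beyond the usual scatter, so compound 2 is the more inhibiting of the pair at this concentration.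

Compound 3, `N#Cc1ccccc1-c1sc2ccccc2c1C=O`, is the next compound in view. It differs from compound 2 in one respect: formyl in place of hydrogen on an aromatic carbon. Compound 3 thus brings together the formyl of compound 1 and the nitrile of compound 2. Within the data shown here, no measured pair shows what adding a formyl alone does to this read-out, so there is no direct guide. The expectation is that the step of a number 1 percentage points lower from compound 2 to compound 3 (within the scatter) will be small, within the scatter, with no firm direction. On that basis compound 3 is expected to give 55%, between 35% and 75%.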

Compound 3, a percentage reported as inhibition, at one concentration (the size of the read-out at that concentration, not a potency): 51%
Compound 3: middle estimate off by 4 percentage points, on the high side; low and high end bracket the measured number.
By their numbers in this assay, from the lowest: compounds 1, 3 and 2 (each within the scatter of the next, the first and the last beyond it).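

In this assay, a formyl in place of hydrogen on an aromatic carbon of the five-membered aromatic ring with 1 sulfur gives a number 5 percentage points lower from compound 2 to compound 3 (within the scatter), so with the nitrile present, this position takes the formyl without a shift that can be told from the usual scatter. The other single change, adding the nitrile, gives a number 9 percentage points higher from compound 1 to compound 3 (within the scatter), so with the formyl present, the nitrile also brings no shift beyond the scatter. Compound 1 and compound 2 differ in more than one place, and compound 3 now links them through two single changes, neither of which can be separated from the scatter on its own.

Nothing measured here gives a reason for these numbers. On these data alone, it remains open whether an amine or a carboxylic acid at this position, or a longer chain in place of the formyl, would move the number beyond the scatter, and whether the formyl would behave the same way on a compound without the nitrile and with a plain phenyl ring.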